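This account rests on a few compounds, and the source may have more. Where it says the series, first, only, none or still open, it means among the compounds named here.

In a functional assay on MCF7 cells (Homo sapiens) for inhibition, read by CCK-8 assay, with a stated time of 72 h (a lower number here means a stronger inhibitor, a higher number a weaker inhibitor), compound 1 (`O=C(/C=C/c1cccnc1)NCCCCCc1cccc(S(=O)(=O)Nc2ccccc2)c1`) gives 12.5 nM and compound 2 (`Cc1ccccc1NS(=O)(=O)c1cccc(CCCCCCNC(=O)/C=C/c2cccnc2)c1`) gives 0.226 nM as the lower of the two numbers, a gap well beyond the scatter. Compound 3 (`CCc1ccc(NS(=O)(=O)c2cccc(CCCCCCNC(=O)/C=C/c3cccnc3)c2)cc1`) differs from compound 2 by having 4-ethylphenyl in place of 2-methylphenyl on a sulfonamide nitrogen. For the measured compounds named here, no measured pair isolates this change, so only a moderate weakening in this assay is expected, possibly little beyond the scatter. The expected size is a 3.5-fold higher number from compound 2 to compound 3 (0.55 log units; beyond the scatter) in this estimate. Compound 3 is estimated at 0.8 nM (expected range 0.12 nM to 5 nM).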

Compound 3, half-maximal inhibitory concentration: 3.64 nM
Estimate against measurement, compound 3: 4.6-fold (0.66 log units) below, within the range that was stated.
By their numbers in this assay, from the lowest: compound 2; then compound 3; then compound 1.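

In this assay, the group on the sulfonamide nitrogen proves to matter strongly: 4-ethylphenyl in place of 2-methylphenyl gives a 16-fold higher number from compound 2 to compound 3 (1.21 log units; beyond the scatter). For the compounds shown here, this is the first step that isolates this position, which the two earlier compounds, differing in more than one place, could not do. Nothing available explains the size of this step. Going by these compounds alone, the single step cannot separate the change of group from the change of its ring position. On these data alone, how a methoxy group, an amine or a carboxylic acid on this phenyl ring would compare remains open.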